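Series notes: pyridyl for aryl on the pyrazole core

The source may hold more compounds than are shown below. What is called first, only, known or untested is meant among the compounds shown, and "the series" means these compounds.

Of the compounds shown here, two have numbers so far. In a functional assay on BJAB cells (Homo sapiens) for antiproliferative activity, with a stated time of 4 days (a higher number here means that more compound is needed for the effect, a lower number that less compound is needed), compound 1, `Cc1ccccc1-c1c(C)nn(-c2nc(-c3ccc(Cl)c(Cl)c3)c(SC(C)C)s2)c1C(=O)O`, gives 5500 nM. Compound 2, `Cc1c(-c2cc(Cl)cc(Cl)c2)c(C(=O)O)nn1-c1nc(-c2cc(Cl)cc(Cl)c2)c(SC(C)C)s1`, gives 2000 nM in this assay. Compound 1 therefore stands at the higher of the two numbers, and the gap to compound 2 lies beyond the usual scatter; the two compounds differ at more than one place, so no single step can be read from them.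

Compound 3, `Cc1cc(-c2c(C)nn(-c3nc(-c4ccc(Cl)c(Cl)c4)c(SC(C)C)s3)c2C(=O)O)cc(C)n1`, is not yet measured. It differs from compound 1 in one place: 2,6-dimethylpyridin-4-yl in place of 2-methylphenyl on an aromatic carbon. The rest of the shared core, including the carboxy group and the methyl group on the five-membered ring, is unchanged.

Within the data shown here, no measured pair isolates this kind of change, so there is nothing to anchor its size. The step from compound 1 to compound 3 is expected to be small, at most a modest move toward a lower number, and is estimated at a 1.4-fold lower number from compound 1 to compound 3 (0.14 log units; within the scatter). Compound 3 is accordingly expected to give about 4000 nM in this assay, with a range from 1500 nM to 12000 nM.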

Compound 3, half-maximal effective concentration: 580 nM
Beside the measured number, compound 3's estimate is 6.9-fold (0.84 log units) above it; the measured number lies below the stated range.
By their numbers in this assay, from the lowest: compound 3; then compound 2; then compound 1.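

Among these compounds, the first single-place step is the change to 2,6-dimethylpyridin-4-yl in place of 2-methylphenyl, which gives a 9.5-fold lower number from compound 1 to compound 3 (0.98 log units; beyond the scatter) in this assay. This shows that the number responds clearly to the group on this aromatic carbon, next to the ring atom that bears a carboxy group and the ring atom that bears a methyl group, something compound 1 and compound 2 could not show because they differ at more than one place. No measurement is at hand that accounts for the size of this step.

The entering group differs from the leaving one both in its ring nitrogen and in its methyl groups, so the compounds shown do not separate these two features; an unsubstituted pyridin-4-yl and a 3,5-dimethylphenyl at this carbon would be the groups to tell them apart. From the compounds shown here alone, it also remains open whether the step would hold with the carboxy group replaced by an amide or a tetrazole, or with other chains in place of the isopropylthio group on the shared core.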